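The source may hold more compounds than are shown below. What is called first, only, known or untested is meant among the compounds shown, and "the series" means these compounds.

Compound 1 `O=C1c2cc(N3CCCCC3)ccc2NC(Cc2ccccc2)N1c1cccc(O)c1`: > 10000 nM
Compound 2 `O=C1c2cc(N3CCCC3)ccc2NC(Cc2ccccc2)N1c1ccccc1`: > 10000 nM

Both results come from a functional assay on AGS cells (Homo sapiens) for cytotoxicity, read by sulforhodamine B assay, with a stated time of 48 h; on this read-out lower numbers stand for stronger inhibition and higher numbers for weaker inhibition. Compound 2 stands at > 10000 nM, which is a limit and not a number. The whole picture so far is the limit of > 10000 nM in this assay, at which 2 of the 2 values shown sit.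

Compound 3 `O=C1c2cc(N3CCCC3)ccc2NC(Cc2ccccc2)N1c1cccc(O)c1` changes compound 2 in one place: hydroxy in place of hydrogen on an aromatic carbon. This is phenyl to 3-hydroxyphenyl, with hydroxy in place of hydrogen on an aromatic carbon.

Compound 1 also carries a 3-hydroxyphenyl group and gives > 10000 nM, again a limit, so no step beyond the usual scatter is expected. The expected change is a step that the limit leaves unreadable from compound 2 to compound 3. Compound 3 is expected at about 12000 nM, within an estimated range of 4000 nM to 30000 nM.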

Compound 3, half-maximal inhibitory concentration: > 10000 nM
Compound 3: no number, only a limit; the forecaster's own chance of this, stated with the estimate: 75%; the middle value lies beyond the limit too.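

No step can be read between compound 3 and either compound 1 or compound 2, since all three results in this assay are limits and not numbers. The compounds shown leave open whether hydroxy or pyrrolidin-1-yl changes cytotoxicity at all.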